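The source may report more compounds than this note shows. Statements on the series, on what has been measured and on what is new or still open speak of the compounds shown alone.

Three measured compounds share one core and differ only in the two aryl groups. Compound 1 `Cc1nc(-c2ccc(Cl)cc2)sc1C(=O)CSc1nc(-c2ccc(Cl)c(Cl)c2)c(C#N)c(=O)[nH]1` gives 83900 nM in a functional assay on U-87MG ATCC cells for antiproliferative activity against U-87 MG (Homo sapiens), read by MTT assay, with a stated time of 48 h; on this read-out lower numbers stand for stronger inhibition and higher numbers for weaker inhibition. Compound 2 `COc1ccc(-c2nc(C)c(C(=O)CSc3nc(-c4ccc(Cl)c(Cl)c4)c(C#N)c(=O)[nH]3)s2)cc1` gives 68500 nM in this assay, and compound 3 `Cc1nc(-c2ccc(Cl)cc2)sc1C(=O)CSc1nc(-c2ccccc2)c(C#N)c(=O)[nH]1` gives 27600 nM. Among these three numbers compound 2 stands second highest: its nearest neighbour is compound 1, separated from it by a 1.2-fold lower number from compound 1 to compound 2 (0.09 log units; within the scatter), a move that stays within the scatter, while its furthest is compound 3, whose number is lower by a gap beyond the scatter.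

Compound 4 `COc1ccc(-c2nc(C)c(C(=O)CSc3nc(-c4cccc(OC)c4)c(C#N)c(=O)[nH]3)s2)cc1` differs from compound 2 by 3-methoxyphenyl in place of 3,4-dichlorophenyl on an aromatic carbon. Among the compounds with values here, the one measured step that bears on this change is a 3.0-fold lower number from compound 1 to compound 3 (0.48 log units; beyond the scatter), a modest move in which the same 3,4-dichlorophenyl leaves, there replaced by a plain phenyl. Because that step a 3.0-fold lower number from compound 1 to compound 3 (0.48 log units; beyond the scatter) lowered the number beyond the scatter, and because the exchange a 1.2-fold lower number from compound 1 to compound 2 (0.09 log units; within the scatter) on the other ring showed that methoxy for chloro changed little, compound 4 is expected to show a modest lowering, a 2.3-fold lower number from compound 2 to compound 4 (0.36 log units; beyond the scatter). The estimate for compound 4 is 30000 nM, with a range from 12000 nM to 75000 nM.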

Compound 4, half-maximal inhibitory concentration: 15300 nM
For compound 4 the middle estimate is 2.0-fold (0.29 log units) above the measured one, within the range that was stated.
By their numbers in this assay, from the lowest: compounds 4 and 3 (each within the scatter of the next); then compounds 2 and 1 (each within the scatter of the next).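

The change at this position, on an aromatic carbon next to the ring nitrogen and ortho to a cyano group, gives a 4.5-fold lower number from compound 2 to compound 4 (0.65 log units; beyond the scatter) in this assay, so removing 3,4-dichlorophenyl lowers the number beyond the scatter on a second background. Within the data shown here, until now, the only reading of this exchange was a 3.0-fold lower number from compound 1 to compound 3 (0.48 log units; beyond the scatter), in which chloro sat on the other aryl ring and a plain phenyl entered; here the other ring carries methoxy and the entering group is itself substituted. The lowering therefore needs neither an unsubstituted phenyl nor a smaller group, as 3,4-dichlorophenyl and 3-methoxyphenyl have the same count of heavy atoms, although 3-methoxyphenyl adds one hydrogen-bond acceptor. No measurement here explains why this exchange lowers the number.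

The compounds shown leave open whether the lowering comes from losing the two chlorine atoms or from gaining the methoxy group, as plain phenyl and 3-methoxyphenyl are not compared on a single background. They also leave open how an aminophenyl or a carboxyphenyl group would behave at this position.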